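Replacing the 1H-indol-4-yl group of compound 2

The source may report more compounds than this note shows. Statements on the series, on what has been measured and on what is new or still open speak of the compounds shown alone.

Of the compounds shown here, two on a shared core have been measured so far. In a physicochemical assay for solubility (a lower number here means a less soluble compound, a higher number a more soluble compound), compound 1 `CNC(=O)c1cc(C(=O)NC2CC2)cn(Cc2cccc3[nH]c(C)nc23)c1=O` reads >= 198 ug/mL and this is a limit of the assay, not a number. Among the measured compounds shown here, compound 2 `CNC(=O)c1cc(C(=O)NC2CC2)cn(Cc2cccc3[nH]ccc23)c1=O` gives 78 ug/mL in this assay and is the only one of the pair with an exact number. Compound 3 `CNC(=O)c1cc(C(=O)NC2CC2)cn(Cc2cccc(OC)c2)c1=O` has not yet been measured. Its difference from compound 2 is 3-methoxyphenyl in place of 1H-indol-4-yl on a saturated chain carbon bound to an aromatic nitrogen and it amounts to 3-methoxyphenyl in place of 1H-indol-4-yl on a saturated chain carbon bound to an aromatic nitrogen. For the measured compounds named here, no measured step shows what such a change does. With compound 2 at 78 ug/mL as the only anchor, a small rise is expected, no larger than the usual scatter. The estimated step of a 1.3-fold higher number from compound 2 to compound 3 (0.11 log units; within the scatter) is therefore modest. In this assay compound 3 is expected at 100 ug/mL within a range of 45 ug/mL to 195 ug/mL once it is measured.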

Compound 3, solubility: 79 ug/mL
Estimate against measurement, compound 3: 1.3-fold (0.10 log units) above; measured number inside the range.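

The change gives a 1.0-fold higher number from compound 2 to compound 3 (0.01 log units; within the scatter), the first step read at this place, on a saturated chain carbon bound to an aromatic nitrogen. In this assay, compound 2 and compound 3 therefore lie within the scatter of each other, although 3-methoxyphenyl has one six-membered aromatic ring where 1H-indol-4-yl has a five-membered and a six-membered aromatic ring, and it has a hydrogen-bond acceptor where 1H-indol-4-yl has a hydrogen-bond donor. No step to compound 1 can be read, because its value is a limit of the assay and not a number: the limit of >= 198 ug/mL in this assay, at which 1 of the 3 values shown sits.

This single step does not show whether other groups at this place would behave in the same way. As far as these compounds go, whether a carboxylic acid or an amine in place of the methoxy group of compound 3 would move the read-out beyond the scatter remains open.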